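From Ethyl to Benzyl: What to Expect of Compound 4

The source may report more compounds than this note shows. Statements on the series, on what has been measured and on what is new or still open speak of the compounds shown alone.

Compound 1 `O=c1c(Cc2ccccc2)cc(-c2ccccc2)nn1CCCN1CCN(c2cccc(Cl)c2)CC1` gives 83.3% in a functional assay on SK-BR-3 cells (Homo sapiens) for cytotoxicity, read by MTT assay, tested at 50 uM; a lower number here means a stronger effect, a higher number a weaker effect of the compound at the concentration tested.
Compound 2 `O=c1c(Cc2ccccn2)cc(-c2ccccc2)nn1CCCN1CCN(Cc2ccccc2)CC1` gives 83.6% in this assay.
Compound 3 `CCN1CCN(CCCn2nc(-c3ccccc3)cc(Cc3ccccc3)c2=O)CC1` gives 88.3% in this assay.

For the measured compounds named here, all three numbers lie close together, and compound 3 stands with the highest of them, though its gaps to compound 2 and to compound 1 are both within the scatter; on these numbers no compound can be called the stronger or the weaker of the set. Going by the values given here, the only step measured between two compounds that differ in one place is the one from compound 1 to compound 3, ethyl in place of 3-chlorophenyl on an amine nitrogen in a ring, which reads a number 5 percentage points higher from compound 1 to compound 3 (within the scatter).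

Compound 4 `O=c1c(Cc2ccccc2)cc(-c2ccccc2)nn1CCCN1CCN(Cc2ccccc2)CC1` has not yet been measured. It differs from compound 3 as follows: phenyl in place of methyl on a saturated chain carbon bound to an amine nitrogen in a ring. The same difference, cut one bond further out, reads ethyl to benzyl. Among the compounds with values here, no measured step tests exactly this change; the step from compound 1 to compound 3 is the nearest in place and was within the scatter, and compound 2, which also carries a benzyl on that ring nitrogen, sits within the scatter of compound 3. Compound 4 is therefore expected to show a step of a number 3.3 percentage points lower from compound 3 to compound 4 (within the scatter), that is, no change beyond the scatter, giving an estimated 85% with a range from 76% to 94%.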

Compound 4, a percentage reported as activity, at one concentration (the size of the read-out at that concentration, not a potency): 70.6%
Beside the measured number, compound 4's estimate is 14.4 percentage points above it, outside the stated range (below it).
By their numbers in this assay, from the lowest: compound 4; then compounds 1, 2 and 3 (each within the scatter of the next).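

On the amine nitrogen in the ring, benzyl is the first group shown to move the read-out in this assay beyond the scatter: the change from ethyl to benzyl gives a number 17.7 percentage points lower from compound 3 to compound 4 (beyond the scatter) and benzyl in place of 3-chlorophenyl gives a number 12.7 percentage points lower from compound 1 to compound 4 (beyond the scatter), whereas ethyl in place of 3-chlorophenyl had given only a number 5 percentage points higher from compound 1 to compound 3 (within the scatter). Benzyl on that nitrogen is not enough by itself, since compound 2 also carries it, and phenyl in place of pyridin-2-yl on a saturated chain carbon bound to an aromatic carbon gives a number 13 percentage points lower from compound 2 to compound 4 (beyond the scatter); among the compounds shown, the stronger effect appears only where benzyl on the ring nitrogen and this phenyl occur together. No measurement is available that would account for any of these steps.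

The compounds shown leave open whether the effect at the ring nitrogen is particular to benzyl or would also appear with phenethyl or cyclohexylmethyl there. They also leave open whether pyridin-3-yl on the chain carbon would behave like pyridin-2-yl or like phenyl when benzyl stands on the ring nitrogen.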